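The compounds below may be only part of what the source reports. "The series", "measured", "known", "first", "only" and "open" are said of these compounds alone.

Compound 1 `CC(C)=CCC/C(C)=C/CC/C(C)=C/CC[C@@H]1[C@@]2(C)CCC(=O)C(C)(C)[C@@H]2CC[C@@]1(C)O` gives 26600 nM in a functional assay on HepG2 cells (Homo sapiens) for cytotoxicity, read by MTT assay, with a stated time of 48 h; a lower number here means a stronger inhibitor, a higher number a weaker inhibitor. Compound 2 `COc1cccc(-n2cc(CO/N=C3\CC[C@]4(C)[C@@H](CC/C=C(\C)CC/C=C(\C)CCC=C(C)C)[C@](C)(O)CC[C@H]4C3(C)C)nn2)c1` gives 51300 nM, and compound 3 `CC(C)=CCC/C(C)=C/CC/C(C)=C/CC[C@@H]1[C@@]2(C)CC/C(=N\OCc3cn(-c4cccc(Br)c4)nn3)C(C)(C)[C@@H]2CC[C@@]1(C)O` gives 39800 nM; this places compound 3 second highest of the three numbers, with both its neighbours within the scatter. Among the measured compounds shown here, the one step measured on this series is a 1.3-fold lower number from compound 2 to compound 3 (0.11 log units; within the scatter), a change that stays within the scatter. Compound 4 `CC(C)=CCC/C(C)=C/CC/C(C)=C/CC[C@@H]1[C@@]2(C)CC/C(=N\OCc3cn(-c4c(Cl)cc([N+](=O)[O-])cc4Cl)nn3)C(C)(C)[C@@H]2CC[C@@]1(C)O` differs from compound 3 by 2,6-dichloro-4-nitrophenyl in place of 3-bromophenyl on an aromatic nitrogen. For the measured compounds named here, only that single step bears on the change, and it shows no movement beyond the scatter, so for compound 4 a step of a 1.1-fold lower number from compound 3 to compound 4 (0.04 log units; within the scatter) is expected, none beyond the scatter. Compound 4 is therefore estimated at 36000 nM in this assay, within a range from 15000 nM to 85000 nM.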

Compound 4, half-maximal inhibitory concentration: 34900 nM
Compound 4: middle estimate off by 1.0-fold (0.01 log units), on the high side; measured number inside the range.
By their numbers in this assay, from the lowest: compounds 1, 4, 3 and 2 (each within the scatter of the next).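

In this assay, exchanging 3-bromophenyl for the larger, more heavily substituted 2,6-dichloro-4-nitrophenyl on the aromatic nitrogen stays within the scatter (a 1.1-fold lower number from compound 3 to compound 4 (0.06 log units; within the scatter)). The same holds against 3-methoxyphenyl (a 1.5-fold lower number from compound 2 to compound 4 (0.17 log units; within the scatter)). Thus, where the earlier step compared only bromo with methoxy on an aromatic carbon, three different aryl groups at this position now cannot be told apart, and no supporting measurement accounts for this.

Still open, as far as these compounds go, is whether any group here can move the number beyond the scatter. An aminophenyl or carboxyphenyl group, or a plain alkyl chain on that nitrogen, might show this.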